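The source may hold more compounds than are shown below. What is called first, only, known or untested is meant among the compounds shown, and "the series" means these compounds.

Measured so far in an assay on isolated protein for inhibition of DNA topoisomerase 1 (Homo sapiens), with a stated time of 30 min, tested at 100 uM; a lower number here means a weaker effect, a higher number a stronger effect of the compound at the concentration tested:
- compound 1 `Oc1ccccc1-c1cc(-c2ccccc2)cc(-c2ccccc2O)n1` gives 0%
- compound 2 `Oc1cccc(-c2cc(-c3ccccc3)cc(-c3ccccc3)n2)c1` gives 12.9%
- compound 3 `Oc1ccc(-c2cc(-c3ccccc3)cc(-c3ccccc3)n2)cc1` gives 52.9%

Compound 3 stands highest of the three numbers in this assay; compound 2 lies nearest, and compound 1 furthest. Going by the values given here, the only step within the measured set, a number 40 percentage points higher from compound 2 to compound 3 (beyond the scatter), came from moving the hydroxyl on one of the outer rings.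

Compound 4 `Oc1ccc(-c2cc(-c3ccccc3)cc(-c3ccsc3)n2)cc1` differs from compound 3 in another place: thiophen-3-yl in place of phenyl on an aromatic carbon. Among the compounds with values here, no measured step concerns such an exchange, so nothing in the data says how large the change in this assay should be. The expectation is therefore a step of no particular size, a number 7.9 percentage points lower from compound 3 to compound 4 (within the scatter), with wide uncertainty. Compound 4 is estimated at 45%, between 15% and 70%.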

Compound 4, a percentage reported as inhibition, at one concentration (the size of the read-out at that concentration, not a potency): 20.4%
Compound 4: middle estimate off by 24.6 percentage points, on the high side; low and high end bracket the measured number.
By their numbers in this assay, from the lowest: compound 1; then compounds 2 and 4 (each within the scatter of the next); then compound 3.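

In this assay, thiophen-3-yl in place of phenyl next to the ring nitrogen gives a number 32.5 percentage points lower from compound 3 to compound 4 (beyond the scatter). So the read-out depends on which aromatic ring sits at this position, and not only on where the hydroxyl sits on the 4-hydroxyphenyl group. Nothing measured here explains why this exchange has such an effect.

On these data alone, whether a furan-3-yl ring, a pyridine ring or an amine at this position would track phenyl or thiophen-3-yl remains open. So does whether the same exchange on the remaining phenyl group would give a similar step.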